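A few compounds are considered here, and "the series" means these few. Any claim that something is new, unique, unknown or untested is made for them only; others in the source may bear on it.

Working notes on an ADME assay on microsomes from liver (Homo sapiens) for metabolic stability; on this read-out higher numbers stand for a longer-lived compound and lower numbers for a shorter-lived compound. Compound 3 (`Cc1nc(C(c2ccc(-c3ccc4cccc(F)c4c3)[nH]c2=O)C(C)C)[nH]c1C`) gives 0.268 h, the top number of the three measured, though not clearly separated from every other compound. Compound 2 (`CC(C)C(c1ccc(-c2ccc3cccc(F)c3c2)[nH]c1=O)N1CCCCC1=O`) gives 0.183 h, and the gap is a 1.5-fold higher number from compound 2 to compound 3 (0.17 log units; within the scatter). Among the measured compounds shown here, compound 1 (`CC(C)C(Cc1ncc[nH]1)c1ccc(-c2ccc3cccc(F)c3c2)[nH]c1=O`) gives 0.106 h, and the only step that clears the scatter is a 2.5-fold higher number from compound 1 to compound 3 (0.40 log units; beyond the scatter).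

Compound 4 (`CC(C)C(Cc1nnn[nH]1)c1ccc(-c2ccc3cccc(F)c3c2)[nH]c1=O`) is still to be measured. The change is (1H-tetrazol-5-yl)methyl in place of 4,5-dimethyl-1H-imidazol-2-yl on a saturated chain carbon bound to an aromatic carbon and a saturated chain carbon: (1H-tetrazol-5-yl)methyl in place of 4,5-dimethyl-1H-imidazol-2-yl, on a saturated chain carbon bound to an aromatic carbon and a saturated chain carbon.

The closest guide is a 2.5-fold higher number from compound 1 to compound 3 (0.40 log units; beyond the scatter), since compound 1 carries (1H-imidazol-2-yl)methyl at this place and the present change runs the other way, back to a group ending in methyl. The remaining step, a 1.7-fold higher number from compound 1 to compound 2 (0.24 log units; within the scatter), stays within the scatter. For the measured compounds named here, no compound with (1H-tetrazol-5-yl)methyl has been measured, so the effect of that ring remains unknown, and the guide is only partial. A lower number is expected, of a size that may not clear the scatter.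

The expected step is a 1.8-fold lower number from compound 3 to compound 4 (0.25 log units; within the scatter). The estimate for compound 4 is 0.15 h, with an expected range of 0.07 h to 0.32 h.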

Compound 4, half-life: > 3 h
Compound 4 gave a limit, no number (the forecaster's own chance of this, stated with the estimate: 3%); at least 20-fold (1.30 log units) between middle value and limit.
By their numbers in this assay, from the lowest: compounds 1, 2 and 3 (each within the scatter of the next, the first and the last beyond it). At a limit, above all of these: compound 4.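

In this assay compound 4 gives > 3 h, which is a limit of the assay and not a number: the limit of > 3 h in this assay, at which 1 of the 4 values shown sits.

Among the compounds shown here, the clearest reading comes from the pair that keeps the methyl link and differs only in the ring, 1H-tetrazol-5-yl in place of 1H-imidazol-2-yl (an at least 28-fold higher number from compound 1 to compound 4 (1.45 log units; beyond the scatter)), so at this place the identity of the ring counts for far more than the earlier compounds suggested, and a methyl link does not by itself mean a short half-life. The same holds against both groups that sit on the saturated chain carbon without that link (an at least 11-fold higher number from compound 3 to compound 4 (1.04 log units; beyond the scatter); an at least 16-fold higher number from compound 2 to compound 4 (1.21 log units; beyond the scatter)), and these large steps dwarf anything seen among compound 1, compound 2 and compound 3.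

On these data alone, how far compound 4 lies past its limit stays unknown, so the true size of all three steps remains open. Also open is whether this behaviour belongs to the tetrazole ring alone, as the compounds shown leave untested a carboxylic acid on the same methyl link, a 1H-tetrazol-5-yl bound directly to the saturated chain carbon, and a longer chain carrying that ring.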